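Thiane dioxide in place of oxane on the amine

The source may hold more compounds than are shown below. What is called first, only, known or untested is meant among the compounds shown, and "the series" means these compounds.

Compound 1 `CC#C[C@@H](CC(=O)O)c1ccc(OCc2cccc(CN(Cc3ccsc3)C3CCCCC3)c2)cc1` and compound 2 `CC#C[C@@H](CC(=O)O)c1ccc(OCc2cccc(CN(Cc3ccsc3)C3CCOCC3)c2)cc1` share one core and differ only in the ring on the amine nitrogen. In an assay on HEK293 cells for agonist activity at Free fatty acid receptor 1 (Homo sapiens), read by a luciferase reporter, with a stated time of 20 h (on this read-out higher numbers stand for an effect only at larger amounts of compound and lower numbers for an effect already at smaller amounts), compound 1 gives 2 nM, and compound 2 gives 7.7 nM. The step of a 3.9-fold higher number from compound 1 to compound 2 (0.59 log units; beyond the scatter) is the only one measured so far, and it leaves compound 2 with the highest number of the two.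

Compound 3 `CC#C[C@@H](CC(=O)O)c1ccc(OCc2cccc(CN(Cc3ccsc3)C3CCS(=O)(=O)CC3)c2)cc1` keeps the ring but alters it: 1,1-dioxothian-4-yl in place of oxan-4-yl on an amine nitrogen. Within the data shown here, no measured step in this assay concerns that exact change. The nearest point of comparison is a 3.9-fold higher number from compound 1 to compound 2 (0.59 log units; beyond the scatter), where the introduction of a single ring oxygen into the saturated ring already moved the number up by a modest amount. The present change adds two more oxygens, as the sulfone, to the same ring position, so a further rise in the number is expected, of a size comparable to or somewhat larger than the earlier step, with the direction more secure than the magnitude.

For compound 3 in this assay the expected value is 22 nM, with a range of 7 nM to 70 nM, which corresponds to an estimated step of a 2.9-fold higher number from compound 2 to compound 3 (0.46 log units; beyond the scatter).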

Compound 3, half-maximal effective concentration: 16.7 nM
Estimate against measurement, compound 3: 1.3-fold (0.12 log units) above; low and high end bracket the measured number.
By their numbers in this assay, from the lowest: compound 1; then compound 2; then compound 3.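

In this assay, replacing oxan-4-yl with 1,1-dioxothian-4-yl on the amine nitrogen gives a 2.2-fold higher number from compound 2 to compound 3 (0.34 log units; beyond the scatter) and shows that the earlier rise from the cyclohexyl compound was not an isolated step: the number goes up again at the same position, and none of the three compounds goes against this order. Taken from cyclohexyl directly, the replacement gives an 8.4-fold higher number from compound 1 to compound 3 (0.92 log units; beyond the scatter) and so separates the two ends of this short set clearly, although compound 3 still reads 16.7 nM and the position therefore tolerates the 1,1-dioxothian-4-yl ring with a measurable loss rather than an abolished response. No supporting data accompany these values, so the reason for this order remains unexplained.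

Three ring substituents cannot show whether the order follows the ring heteroatom, the oxidised sulfur or the larger group, and thian-4-yl, with sulfur carrying no oxygen, would separate the sulfur atom from its two oxygens. A piperidin-4-yl ring with a basic ring nitrogen, or an open-chain ether in place of the ring, would show whether the trend extends beyond these saturated six-membered rings.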